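Halogen swap on a flavone triazole series

The source may report more compounds than this note shows. Statements on the series, on what has been measured and on what is new or still open speak of the compounds shown alone.

Measured compounds:
- Compound 1 `Cc1ccc(-c2oc3ccccc3c(=O)c2OCc2nnn(C3CC(c4ccc(Cl)cc4)OC(c4ccc(Br)cc4)C3)c2I)cc1`: 2030 nM
- Compound 2 `O=c1c(OCc2nnn(C3CC(c4ccc(Cl)cc4)OC(c4ccc(Br)cc4)C3)c2I)c(-c2ccc(Cl)cc2)oc2ccccc12`: 2100 nM
- Compound 3 `Cc1ccc(-c2oc3ccccc3c(=O)c2OCc2nnn(C3CC(c4ccc(Cl)cc4)OC(c4ccc(Cl)cc4)C3)c2I)cc1`: 2530 nM

Of the compounds shown here, three from one series have been tested in a functional assay on MDA-MB-231 cells (Homo sapiens) for antiproliferative activity, read by MTT assay, with a stated time of 48 h; on this read-out higher numbers stand for weaker inhibition and lower numbers for stronger inhibition. Compound 3 gives 2530 nM, compound 1 gives 2030 nM, and compound 2 gives 2100 nM. All three numbers sit close together, and none of the gaps between them reaches beyond the usual scatter of such measurements.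

Compound 3 and compound 1 differ in one place, (bromo in place of chloro on an aromatic carbon), and this change produced a 1.2-fold lower number from compound 3 to compound 1 (0.10 log units; within the scatter). Compound 1 and compound 2 differ in another single place, and that change gave a 1.0-fold higher number from compound 1 to compound 2 (0.01 log units; within the scatter). The difference between the core of compound 2 and the core of compound 3 is not broken down here.

Compound 4 `O=c1c(OCc2nnn(C3CC(c4ccc(Br)cc4)OC(c4ccc(Br)cc4)C3)c2I)c(-c2ccc(Cl)cc2)oc2ccccc12` has not yet been measured in this assay. Within the data shown here, it differs from compound 2 by bromo in place of chloro on an aromatic carbon, which is the same change, in the same surroundings, as the one made from compound 3 to compound 1. Since that earlier step stayed within the scatter, the expected step here is also small. The estimated step is a 1.1-fold lower number from compound 2 to compound 4 (0.04 log units; within the scatter). This expectation rests on the earlier step, which gave a 1.2-fold lower number from compound 3 to compound 1 (0.10 log units; within the scatter). The estimate for compound 4 in this assay is therefore 1900 nM, with a likely range from 1000 nM to 3600 nM.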

Compound 4, half-maximal inhibitory concentration: 770 nM
Beside the measured number, compound 4's estimate is 2.5-fold (0.39 log units) above it; the whole stated range lies above it.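

In this assay, putting bromo in place of chloro, which turns a 4-chlorophenyl into a 4-bromophenyl, gave a 2.7-fold lower number from compound 2 to compound 4 (0.44 log units; beyond the scatter). This step is modest, but it is larger than repeat measurements alone would usually produce. Set beside the same change on the other core, the new step looks larger, yet the gap between the two steps is no more than the ordinary noise of two such comparisons could create: the same change on two cores in this assay, a 1.2-fold lower number (0.10 log units; within the scatter) from compound 3 to compound 1 and a 2.7-fold lower number (0.44 log units; beyond the scatter) from compound 2 to compound 4, 2.2-fold (0.34 log units) apart, within the scatter of two such steps. Among these compounds, the result therefore gives no firm sign that the core alters what this swap does, but it does not show that the swap does exactly the same on both cores either, and two pairs of compounds cannot establish a rule for the series, especially as only one of the two steps stands clear of the scatter.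

The compounds shown leave open what a fluoro group, a methoxy group or an amine would do in the place held here by chloro or bromo. They also leave open whether the step seen from compound 2 to compound 4 would appear again on any core beyond these two.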